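Swapping Difluorophenyl for Methoxyphenyl on the Ring Amide

The source may report more compounds than this note shows. Statements on the series, on what has been measured and on what is new or still open speak of the compounds shown alone.

Among the compounds with values here, compound 2 `O=C1c2cc(COc3ccccc3)nn2CCN1c1ccc(F)cc1F` gives 101% in a functional assay on HEK293 cells for positive allosteric modulation of metabotropic glutamate receptor 5 (Homo sapiens), read by calcium flux (a lower number here means a smaller maximal response, a higher number a larger maximal response), the highest of the two numbers so far. Compound 1 `O=C1c2cc(COc3ccccc3)nn2CCN1c1ccccc1F` gives 86%, and the step of a number 15 percentage points higher from compound 1 to compound 2 (beyond the scatter) came from fluoro in place of hydrogen on an aromatic carbon. Compound 3 `COc1ccc(N2CCn3nc(COc4ccccc4)cc3C2=O)cc1` has not been measured; it differs from compound 2 by 4-methoxyphenyl in place of 2,4-difluorophenyl on an amide-type nitrogen in a ring. Within the data shown here, no measured step removes fluorines or adds a methoxy group, so the single known step bears on this change only loosely, and a modest step in either direction remains possible. Compound 3 is therefore estimated to reach 88%, between 60% and 110%, an expected step of a number 13 percentage points lower from compound 2 to compound 3 (beyond the scatter).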

Compound 3, largest response reached (Emax), in percent of the reference or control that the assay uses: 58%
Beside the measured number, compound 3's estimate is 30 percentage points above it; the whole stated range lies above it.
By their numbers in this assay, from the lowest: compound 3; then compound 1; then compound 2.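

On the amide-type nitrogen in a ring, the choice of aromatic group can move the maximal response by far more than the earlier fluoro step showed: 4-methoxyphenyl in place of 2,4-difluorophenyl brings a number 43 percentage points lower from compound 2 to compound 3 (beyond the scatter) in this assay. In place of 2-fluorophenyl, the same group brings a number 28 percentage points lower from compound 1 to compound 3 (beyond the scatter), so it falls below both fluorinated rings. Nothing available explains this drop.

From the compounds shown here alone, the fluorines leave and the methoxy group enters in a single change, so the share of each stays open. Going by these compounds, how a 4-chlorophenyl group or a pyridine ring would fare on this nitrogen also remains unknown.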